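The source may report more compounds than this note shows. Statements on the series, on what has been measured and on what is new or still open speak of the compounds shown alone.

Compound 1, `Fc1ccc(C2CC(c3ccc(Cl)cc3)=NN2c2ccc(-c3ccccc3)nn2)cc1`, in a functional assay on Caco-2 cells (Homo sapiens) for antiproliferative activity, read by MTT assay, with a stated time of 24 h (on this read-out lower numbers stand for stronger inhibition and higher numbers for weaker inhibition), gives > 100000 nM, which is a limit of the assay.
Compound 2, `COc1ccc(C2CC(c3ccc(Cl)cc3)=NN2c2ccc(-c3ccccc3)nn2)cc1`, in this assay gives > 100000 nM, also a limit of the assay.

Compound 2 therefore stands at the limit of > 100000 nM in this assay, at which 2 of the 2 values shown sit, with no number of its own. Among the compounds with values here, the only measured step, a step that the two limits leave unreadable from compound 1 to compound 2, is one that both limits leave unreadable, so its size tells nothing. Compound 3, `COc1ccc(C2CC(c3ccc(Cl)cc3)=NN2c2ccc(-c3ccccc3)nn2)c(OC)c1`, is compound 2 with methoxy in place of hydrogen on an aromatic carbon. Within the data shown here, the one step that bears on this change gives no readable size, so no step beyond the scatter can be expected in either direction in this assay, and the most likely outcome is another limit. Compound 3 is therefore expected to give 100000 nM, with a range from 30000 nM to 300000 nM. The estimate for compound 3 corresponds to a step of a number no higher from compound 2 to compound 3 (the limit leaves the size open), which is expected to lie within the scatter.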

Compound 3, half-maximal inhibitory concentration: > 100000 nM
Compound 3: only a limit was reported; the forecaster's own chance of this, stated with the estimate: 75%; the middle value lies on the limit itself.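

Within the data shown here, no step among compound 1, compound 2 and compound 3 can be read, since all three values are limits of the assay: the limit of > 100000 nM in this assay, at which 3 of the 3 values shown sit. The compounds shown leave open how strongly any of them acts in this assay, and whether methoxy in place of hydrogen changes that at all.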